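Oxime series: a second swap at the chloro position

A few compounds are considered here, and "the series" means these few. Any claim that something is new, unique, unknown or untested is made for them only; others in the source may bear on it.

The series shares the core of compound 1 `O/N=C(\C=C\c1ccc(Cl)cc1)c1ccc(Cl)cc1`. For the measured compounds named here, in a functional assay (Mus musculus, strain Balb/c) for inhibition, read by ELISA, with a stated time of 72 h (on this read-out higher numbers stand for weaker inhibition and lower numbers for stronger inhibition), compound 1 gives 9150 nM, the highest of the two numbers measured so far; the nearest is compound 2 `COc1ccc(/C=C/C(=N\O)c2ccc(Cl)cc2)cc1`, which in this assay gives 5850 nM. Going by the values given here, the only measured step, methoxy in place of chloro on an aromatic carbon, a 1.6-fold lower number from compound 1 to compound 2 (0.19 log units; within the scatter), stays within the scatter. Compound 3 `Cc1ccc(C(/C=C/c2ccc(Cl)cc2)=N/O)cc1` differs from compound 1 by methyl in place of chloro on an aromatic carbon. Because a 1.6-fold lower number from compound 1 to compound 2 (0.19 log units; within the scatter) stayed within the scatter, compound 3 is expected to show no step beyond the scatter in this assay. The estimate for compound 3 in this assay is 8000 nM, ranging from 3000 nM to 20000 nM, meaning a 1.1-fold lower number from compound 1 to compound 3 (0.06 log units; within the scatter).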

Compound 3, half-maximal inhibitory concentration: 11600 nM
The estimate for compound 3 lay 1.5-fold (0.16 log units) below the measured number; the range from low to high includes it.
By their numbers in this assay, from the lowest: compounds 2, 1 and 3 (each within the scatter of the next).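

Methyl in place of chloro gives a 1.3-fold higher number from compound 1 to compound 3 (0.10 log units; within the scatter) in this assay. This swap replaces the other chloro of compound 1, not the one replaced by methoxy in compound 2, so each chloro now has one replacement, and neither step leaves the scatter. No evidence at hand bears on this result.

For the compounds shown here, each position has been probed with only one group, so an amine, a carboxylic acid or a longer chain at either chloro position remains open. Also open, going by these compounds, is whether replacing both chloro groups together would move the number beyond the scatter.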